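From Compound 2 to Compound 3: Amino Gives Way to Iodo

A few compounds are considered here, and "the series" means these few. Any claim that something is new, unique, unknown or untested is made for them only; others in the source may bear on it.

Of the compounds shown here, two have so far been tested in a functional assay on FM3A cells (Homo sapiens) for inhibition, with FM3A (Mus musculus) as the target; a higher number here means a weaker inhibitor, a lower number a stronger inhibitor. Compound 1 `CC(=O)OC(C)n1cnc2c(Cl)nc(N)nc21` reaches only a limit of the assay, > 500000 nM. Compound 2 `CC(=O)OCCOn1cnc2c(Cl)nc(N)nc21` likewise reaches only a limit, > 500000 nM. Both stand at the same ceiling, (the limit of > 500000 nM in this assay, at which 2 of the 2 values shown sit). Compound 3 `CC(=O)OCCOn1cnc2c(Cl)nc(I)nc21` differs from compound 2 in one place: iodo in place of amino on an aromatic carbon. Among the measured compounds shown here, with no measured step between compounds to lean on, no change beyond the scatter is expected in this assay, and compound 3 is expected most likely to return another limit. The estimated value for compound 3 is 500000 nM, within 100000 nM to 1000000 nM. The expected step is a number no higher from compound 2 to compound 3 (the limit leaves the size open).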

Compound 3, half-maximal inhibitory concentration: 34000 nM
The estimate for compound 3 lay 15-fold (1.17 log units) above the measured number; measured number outside the range, below it.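

This position is not indifferent to what sits on it: iodo in place of amino on this aromatic carbon, between two ring nitrogen atoms, gives an at least 14-fold lower number from compound 2 to compound 3 (1.16 log units; beyond the scatter) in this assay. Compound 3 is thus the first compound shown to give a number rather than a limit. The full size of the step stays unknown because compound 2 marks only a limit: the limit of > 500000 nM in this assay, at which 2 of the 3 values shown sit.

As far as these compounds go, what bromo or a methyl group would give at this position remains open. So does whether the same change would lower the number for compound 1, since this rests on a single pair.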